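The source may report more compounds than this note shows. Statements on the series, on what has been measured and on what is new or still open speak of the compounds shown alone.

Compound 1 `Cc1nc(C(=O)Nc2ccc(Cl)c(-c3nnc4c(Cl)cccn34)c2)cs1` gives 74300 nM in a functional assay on U-251 cells (Homo sapiens) for antiproliferative activity, read by MTT assay, with a stated time of 72 h; a lower number here means a stronger inhibitor, a higher number a weaker inhibitor. Compound 2 `O=C(Nc1ccc(Cl)c(-c2nnc3c(Cl)cccn23)c1)c1ccc(C(F)(F)F)cc1F` reaches only the limit > 100000 nM in this assay. Compound 3 `Cc1cc(Cl)ccc1C(=O)Nc1ccc(Cl)c(-c2nnc3c(Cl)cccn23)c1` likewise reaches only the limit > 100000 nM in this assay.

Compound 3 thus stands at the edge of what this assay reports: its value is a limit, not a number, and it shares that position with compound 2, as the limit of > 100000 nM in this assay, at which 2 of the 3 values shown sit, shows. Only compound 1 has a measured number. Among the measured compounds shown here, the one step that can be stated, an at least 1.3-fold higher number from compound 1 to compound 3 (0.12 log units; that floor lies within the scatter), sets a floor that lies within the scatter, so no real change between the two can be claimed.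

Compound 4 `O=C(Nc1ccc(Cl)c(-c2nnc3c(Cl)cccn23)c1)c1ccccc1Cl` differs from compound 3 in one place: 2-chlorophenyl in place of 4-chloro-2-methylphenyl on a carbonyl carbon. For the measured compounds named here, no measured step touches this change. Going by the values given here, the one step that exists concerns a different group on the same carbonyl carbon and is itself undecided. There is therefore no basis to expect a step beyond the scatter in this assay, in either direction; the more likely outcome is that compound 4 also ends at a limit.

Compound 4 is accordingly expected to give about 100000 nM in this assay, within 30000 nM to 300000 nM, which means an expected step of a number no higher from compound 3 to compound 4 (the limit leaves the size open).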

Compound 4, half-maximal inhibitory concentration: > 100000 nM
Compound 4 gave a limit, no number (the forecaster's own chance of this, stated with the estimate: 65%); the middle value sits exactly at the limit.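

Compound 4 brings a third group with a six-membered aromatic ring of carbon only onto this carbonyl carbon, and the result is again a limit, > 100000 nM in this assay. Compound 3 and compound 4 both end at limits, so the step between them cannot be read, and losing the methyl group from 4-chloro-2-methylphenyl and moving to 2-chlorophenyl shows no measurable consequence here. The comparison with the one compound that has a number, an at least 1.3-fold higher number from compound 1 to compound 4 (0.12 log units; that floor lies within the scatter), sets only a floor, so compound 4 cannot be separated from compound 1, and the only pattern is a shared end point for compound 2, compound 3 and compound 4, with compound 1 standing apart only in having a number: the limit of > 100000 nM in this assay, at which 3 of the 4 values shown sit.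

Going by these compounds, whether a group such as a piperidine or a carboxylic acid on this carbonyl carbon would give a value clearly beyond the scatter from that of compound 1 stays open. Also open is whether replacing a chlorine on the shared core with an amine would move any of these compounds off the limit.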